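From 2-Methoxyphenyl to 4-Nitrophenyl on the Side Chain

A few compounds are considered here, and "the series" means these few. Any claim that something is new, unique, unknown or untested is made for them only; others in the source may bear on it.

In a functional assay on HeLa cells (Homo sapiens) for cytotoxicity, read by WST assay, with a stated time of 48 h (on this read-out higher numbers stand for weaker inhibition and lower numbers for stronger inhibition), compound 1 `CCCCCC/C=C/C[C@H]1C[C@@H]([C@@H](O)c2ccccc2)CO[C@@H]1c1ccccc1` gives 7400 nM and compound 2 `COc1ccccc1/C=C/C[C@H]1C[C@@H]([C@@H](O)c2ccccc2)CO[C@@H]1c1ccccc1` gives 14700 nM on the same shared core. Among the measured compounds shown here, compound 2 therefore stands level with compound 1, the only other measured compound. Compound 3 `O=[N+]([O-])c1ccc(/C=C/C[C@H]2C[C@@H]([C@@H](O)c3ccccc3)CO[C@@H]2c2ccccc2)cc1` is still unmeasured and differs from compound 2 as follows: 4-nitrophenyl in place of 2-methoxyphenyl on a double-bonded chain carbon bound to a double-bonded chain carbon. In words, it has 4-nitrophenyl in place of 2-methoxyphenyl on a double-bonded chain carbon bound to a double-bonded chain carbon. For the measured compounds named here, only one measured step changes this same place, replacing hexyl with 2-methoxyphenyl, and it is a 2.0-fold higher number from compound 1 to compound 2 (0.30 log units; within the scatter) in size. That single step gives no direction to follow, so no change beyond the scatter is expected in this assay for the new group. The expected step is a 1.2-fold lower number from compound 2 to compound 3 (0.09 log units; within the scatter) in this estimate. For compound 3 the estimated value is 12000 nM, with an expected range from 4000 nM to 35000 nM as its bounds.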

Compound 3, half-maximal inhibitory concentration: 12400 nM
Estimate against measurement, compound 3: 1.0-fold (0.01 log units) below, and the stated range covers the measured number.
By their numbers in this assay, from the lowest: compounds 1, 3 and 2 (each within the scatter of the next).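

In this assay, the change from 2-methoxyphenyl to 4-nitrophenyl on a double-bonded chain carbon bound to a double-bonded chain carbon gives a small step (a 1.2-fold lower number from compound 2 to compound 3 (0.07 log units; within the scatter)), and the change from hexyl to 4-nitrophenyl at the same place gives another (a 1.7-fold higher number from compound 1 to compound 3 (0.22 log units; within the scatter)). Hexyl and two differently substituted aromatic rings have now been compared here, and all three compounds lie within the scatter of one another, so this read-out does not separate them. Nothing measured here gives a reason for this result.

Still open, from the compounds shown here alone, is whether an amine or a carboxylic acid at this place would shift the number beyond the scatter. A chain longer than hexyl could also be informative, since only three groups are shown at this place.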